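Quinone-bearing terpenoid: methoxy in place of hydrogen

A few compounds are considered here, and "the series" means these few. Any claim that something is new, unique, unknown or untested is made for them only; others in the source may bear on it.

Compound 1 `CC1=CCC[C@H]2[C@](C)(CC3=CC(=O)C=CC3=O)[C@@H](C)CC[C@]12C` was examined in an ADME assay on PBMC cells (Homo sapiens) for cytotoxicity, read by MTT assay (on this read-out higher numbers stand for weaker inhibition and lower numbers for stronger inhibition), where compound 1 gives 4800 nM. Of the two numbers recorded so far, compound 1 stands lowest; its nearest neighbour is compound 2 `CC1=CCC[C@H]2[C@](C)(CC3=CC(=O)C(Sc4ccccc4)=CC3=O)[C@@H](C)CC[C@]12C`, which in this assay gives 9900 nM. Among the measured compounds shown here, the single measured step, a 2.1-fold higher number from compound 1 to compound 2 (0.31 log units; beyond the scatter), is the only one that bears on the question at hand.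

Compound 3 `COC1=CC(=O)C=C(C[C@]2(C)[C@@H](C)CC[C@]3(C)C(C)=CCC[C@@H]23)C1=O` has not yet been measured. It differs from compound 1 by methoxy in place of hydrogen on a double-bonded ring carbon. For the measured compounds named here, the one measured step replaces a hydrogen on a double-bonded ring carbon of the same quinone ring with a much larger group, and it moved the number only modestly, just beyond the scatter. Going by the values given here, a methoxy group is a smaller entering group than phenylsulfanyl, and no measured pair shows what such a group does on this ring, so the best that can be expected for compound 3 is a step of about the same direction but no larger, and possibly one lost in the scatter.

Compound 3 is therefore estimated at 6500 nM, with a range of 2800 nM to 15000 nM; this estimate means an expected step of a 1.4-fold higher number from compound 1 to compound 3 (0.13 log units; within the scatter).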

Compound 3, half-maximal inhibitory concentration: 5900 nM
Beside the measured number, compound 3's estimate is 1.1-fold (0.04 log units) above it; the measured number falls inside the stated range.
By their numbers in this assay, from the lowest: compounds 1, 3 and 2 (each within the scatter of the next, the first and the last beyond it).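

The methoxy step, a 1.2-fold higher number from compound 1 to compound 3 (0.09 log units; within the scatter), shows that on a double-bonded ring carbon, two ring bonds from the ring atom that bears a large group, an entering group of 2 heavy atoms leaves compound 3 indistinguishable from compound 1 in this assay. Among the compounds shown here, this differs from the only earlier step, the phenylsulfanyl replacement, a 2.1-fold higher number from compound 1 to compound 2 (0.31 log units; beyond the scatter), which lay beyond the scatter, though that change involves a different entering group and so does not isolate the effect of any one feature. No measurement available here explains why the methoxy step stays within the scatter.

The compounds shown leave open whether an amine or a longer chain such as ethoxy, placed on this same ring carbon, would also stay within the scatter of compound 1, or whether either would move the number as far as phenylsulfanyl did. They also leave open whether methoxy on another ring carbon of the quinone would give the same result, since this single pair speaks only for the one place.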